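Swapping the aryl group on the piperazine of compound 1

The compounds below may be only part of what the source reports. "The series", "measured", "known", "first", "only" and "open" are said of these compounds alone.

Compound 1 `CCCc1nc(-c2ccccc2)c(CNCCCN2CCN(c3ccccc3F)CC2)o1` was tested in an assay on HEK293 cells for inhibition of Voltage-dependent T-type calcium channel subunit alpha-1G (Homo sapiens), read by fluorescence, tested at 10 uM (on this read-out higher numbers stand for more inhibition at the one concentration tested (going by the name of the read-out) and lower numbers for less inhibition), and gave 54.4%. Compound 2 `CCCc1nc(-c2ccccc2)c(CNCCN2CCN(c3ccc(C)cc3)CC2)o1`, which carries a shorter linker and a different aryl group on the ring nitrogen, was tested in this assay and gave 48.1%. The two numbers lie within the usual scatter of one another, so the pair shows no difference beyond the scatter. Among the compounds with values here, no step between two measured compounds differing in a single place is recorded.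

Compound 3 `CCCc1nc(-c2ccccc2)c(CNCCCN2CCN(c3ccc(C)cc3)CC2)o1` is the next compound considered. It differs from compound 1 in that (4-methylphenyl in place of 2-fluorophenyl on an amine nitrogen in a ring). With only these two values to rest on, the step from compound 1 to compound 3 in this assay is expected to be small, and it is estimated at a number 4.4 percentage points lower from compound 1 to compound 3 (within the scatter), essentially none beyond the scatter. Compound 3 is therefore estimated to give 50% in this assay, within a range of 34% to 66%.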

Compound 3, a percentage reported as inhibition, at one concentration (the size of the read-out at that concentration, not a potency): 53.9%
The estimate for compound 3 lay 3.9 percentage points below the measured number, within the range that was stated.
By their numbers in this assay, from the lowest: compounds 2, 3 and 1 (each within the scatter of the next).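

Within the data shown here, compound 3 supplies the first comparison in which only one place differs: this assay gives a number 0.5 percentage points lower from compound 1 to compound 3 (within the scatter) for 4-methylphenyl in place of 2-fluorophenyl on an amine nitrogen in a ring. At this place, then, these two aryl groups cannot be told apart by this read-out at the one concentration tested, so the exchange of fluorine on the phenyl ring for methyl leaves no mark beyond the scatter. Nothing available here accounts for this result or ties it to any property of either group.

Still open, from the compounds shown here alone, is whether this place accepts groups of a different kind, such as a phenyl ring carrying a carboxylic acid or an amine, or a pyridine ring. Also open, going by these compounds, is how a longer chain between the amine nitrogen and the piperazine would read in this assay and whether potency, rather than inhibition at one concentration, would separate compound 1 and compound 3.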